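The source may report more compounds than this note shows. Statements on the series, on what has been measured and on what is new or still open speak of the compounds shown alone.

Measured compounds:
Compound 1 `COc1ccc(CNC(=O)/C=C/c2coc3cc(O)ccc3c2=O)cc1`; in a functional assay on A549 cells (Homo sapiens) for inhibition, read by MTT assay, with a stated time of 48 h (a lower number here means a stronger inhibitor, a higher number a weaker inhibitor), compound 1 gives only the limit > 100000 nM.
Compound 2 `O=C(/C=C/c1coc2cc(O)ccc2c1=O)NCc1ccccc1`; in this assay compound 2 gives only the limit > 100000 nM.
Compound 3 `O=C(/C=C/c1coc2cc(O)ccc2c1=O)NCc1ccc(F)cc1`; in this assay compound 3 gives only the limit > 100000 nM.

Compound 3 stands at the limit of this assay, as do the two others; see (the limit of > 100000 nM in this assay, at which 3 of the 3 values shown sit). No ordering among the three can be read from these numbers.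

Compound 4 `Cc1ccccc1NC(=O)/C=C/c1coc2cc(O)ccc2c1=O` differs from compound 3 by 2-methylphenyl in place of 4-fluorobenzyl on an amide-type nitrogen. The steps measured so far all change the aromatic substituent of the benzyl group: a step that the two limits leave unreadable from compound 1 to compound 2, a step that the two limits leave unreadable from compound 1 to compound 3, a step that the two limits leave unreadable from compound 2 to compound 3. Each of them is unreadable, since both ends sit at the limit, so no size or direction can be carried over to the amide substituent change in compound 4.

With every measured value at the limit, the expectation for compound 4 in this assay is that it again sits at or near the limit, with the step from compound 3 to compound 4 expected as a number no higher from compound 3 to compound 4 (the limit leaves the size open). Compound 4 is estimated at 100000 nM, expected range 30000 nM to 300000 nM.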

Compound 4, half-maximal inhibitory concentration: > 100000 nM
Compound 4: no number, only a limit (the forecaster's own chance of this, stated with the estimate: 75%); the middle value sits exactly at the limit.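

No step to compound 4 from compound 2 or compound 3 can be read in this assay, because each of these compounds gives only a limit: the limit of > 100000 nM in this assay, at which 4 of the 4 values shown sit. The compounds shown leave open how strongly any of them inhibits and whether changing the amide substituent alters inhibition at all.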